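Capping the hydroxy of compound 2 with acetyl

A few compounds are considered here, and "the series" means these few. Any claim that something is new, unique, unknown or untested is made for them only; others in the source may bear on it.

Compound 1 `CC(=O)O[C@@H]1OC(=O)[C@](C)(C(C)=O)[C@@H]1C` is measured in a functional assay on MCF7 cells (Homo sapiens) for cytotoxicity, read by MTT assay (a higher number here means a weaker inhibitor, a lower number a stronger inhibitor), at 6000 nM. For compound 2 `CC(=O)O[C@@H]1OC(=O)[C@](O)(C(C)=O)[C@@H]1C` this assay gives only a limit, > 50000 nM. The step of an at least 8.3-fold higher number from compound 1 to compound 2 (0.92 log units; beyond the scatter) is the only one measured, and its end point rests on (the limit of > 50000 nM in this assay, at which 1 of the 2 values shown sits). Compound 3 `CC(=O)O[C@@H]1OC(=O)[C@](OC(C)=O)(C(C)=O)[C@@H]1C` differs from compound 2 by acetyl in place of hydrogen on an oxygen on a saturated carbon. That measured step concerns the same saturated ring carbon but went from methyl to hydroxy, not from hydroxy to acetoxy, so it bears only loosely on the present change. The step of an at least 1.6-fold lower number from compound 2 to compound 3 (0.22 log units; that floor lies within the scatter) is expected to run downward, recovering part of the earlier weakening. Compound 3 is therefore estimated at 30000 nM, between 6000 nM and 100000 nM.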

Compound 3, half-maximal inhibitory concentration: > 50000 nM
Compound 3 ended at the assay's limit; the forecaster's own chance of this, stated with the estimate: 45%; middle value at least 1.6-fold (0.22 log units) away from the limit.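

In this assay compound 3 gives > 50000 nM, which is a limit of the assay. Acetoxy in place of methyl on the saturated ring carbon gives an at least 8.3-fold higher number from compound 1 to compound 3 (0.92 log units; beyond the scatter), so acetyl capping of the hydroxy does not restore a level like that of the methyl compound. The step between the two limits cannot be read, and methyl remains the only group shown on this carbon with a number rather than a limit: the limit of > 50000 nM in this assay, at which 2 of the 3 values shown sit.

As far as these compounds go, whether ethyl, a longer chain or an amine on this carbon gives a readable value stays open.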